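A cyclopentyl arm replaces the benzyl-triazole of compound 2

This account rests on a few compounds, and the source may have more. Where it says the series, first, only, none or still open, it means among the compounds named here.

Compound 1 `CNc1ncc2c(-c3ccc(N4CCNCC4)nc3)nn(CC3CCCC3)c2n1`: in an assay on isolated protein for inhibition of RAC-alpha serine/threonine-protein kinase (Homo sapiens), read by 33P incorporation, in the presence of a further agent that is not named here (on this read-out lower numbers stand for stronger inhibition and higher numbers for weaker inhibition), compound 1 gives > 10000 nM, which is a limit of the assay.
Compound 2 `CNc1ncc2c(-c3ccc(N4CCN(C)CC4)nc3)nn(Cc3cn(Cc4ccccc4)nn3)c2n1`: in this assay compound 2 gives > 10000 nM, again a limit.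
Compound 3 `CNc1ncc2c(-c3ccc(N4CCN(C(=O)C(C)(C)C)CC4)nc3)nn(Cc3cn(Cc4ccccc4)nn3)c2n1`: in this assay compound 3 gives > 10000 nM, also a limit.

Compound 2 therefore stands at the limit of this assay, and so does every other value measured here, as the limit of > 10000 nM in this assay, at which 3 of the 3 values shown sit, records. Going by the values given here, the only measured step, a step that the two limits leave unreadable from compound 2 to compound 3, runs between two limits and cannot be read for size or direction. Compound 4 `CNc1ncc2c(-c3ccc(N4CCN(C)CC4)nc3)nn(CC3CCCC3)c2n1` differs from compound 2 in one place: cyclopentyl in place of 1-benzyl-1H-1,2,3-triazol-4-yl on a saturated chain carbon bound to an aromatic nitrogen. Compound 1 carries the same cyclopentyl group, and its value in this assay is a limit. Among the compounds with values here, no measured step bears on the cyclopentyl change itself, so nothing in the numbers points to a move away from the limit in either direction. Compound 4 is expected to stay at the limit as well, with the step that the limit leaves unreadable from compound 2 to compound 4 estimated as none beyond the scatter. The estimate for compound 4 in this assay is 20000 nM, within 6000 nM to 60000 nM.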

Compound 4, half-maximal inhibitory concentration: > 10000 nM
Compound 4: no number, only a limit; the forecaster's own chance of this, stated with the estimate: 80%; the middle value does not contradict the limit.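

The result for compound 4 is again a limit, so no new step can be read from compound 1 or compound 2 to compound 4, because all the values sit at the same limit: the limit of > 10000 nM in this assay, at which 4 of the 4 values shown sit.

The compounds shown leave open whether any change to the shared core would give a measurable value, and how large the cyclopentyl and methyl steps really are.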